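The source may report more compounds than this note shows. Statements on the series, on what has been measured and on what is new or still open speak of the compounds shown alone.

Compound 1 `O=C(Nc1ccc(Cl)cc1)c1c(NC(=O)C(F)(F)F)sc2c1CCCCC2` is one of a pair of amides that share the same core. In an ADME assay on THP-1 cells (Homo sapiens) for cytotoxicity (on this read-out higher numbers stand for lower toxicity in this test and lower numbers for higher toxicity in this test), compound 1 gives only a limit of the test, > 50000 nM, and not a measured number. Its companion, compound 2 `COc1ccc(NC(=O)c2c(NC(=O)c3ccccc3)sc3c2CCCCC3)cc1`, carries a different pair of amide groups on that core. In this assay compound 2 likewise stops at a limit, > 50000 nM. Both compounds sit at the limit of > 50000 nM in this assay, at which 2 of the 2 values shown sit, so no order can be drawn between them, and compound 1 stands where every shown value stands: at the limit, with no finite number behind it. Compound 3 `O=C(Nc1ccccc1)c1c(NC(=O)C(F)(F)F)sc2c1CCCCC2` has not yet been run in this assay. It differs from compound 1 in one spot: hydrogen in place of chloro on an aromatic carbon. Within the data shown here, no measured pair shows what this change does here, so the expectation rests on the two limits alone. In this assay the expected step is none beyond the scatter, a step that the limit leaves unreadable from compound 1 to compound 3. Compound 3 is therefore expected to come out around 80000 nM, most likely again only as a limit, within a range from 30000 nM to 250000 nM.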

Compound 3, half-maximal cytotoxic concentration: > 50000 nM
Compound 3 gave a limit, no number (the forecaster's own chance of this, stated with the estimate: 85%); the middle value does not contradict the limit.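

In this assay, compound 1 and compound 3 both stop at a limit of the test and give no number, so no step can be read between them: the limit of > 50000 nM in this assay, at which 3 of the 3 values shown sit.

The compounds shown leave open where the true values of compound 1 and compound 3 lie, and whether hydrogen in place of chloro changes this read-out at all.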